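A few compounds are considered here, and "the series" means these few. Any claim that something is new, unique, unknown or untested is made for them only; others in the source may bear on it.

Working notes on the coumarin amino-alcohol series, toxicity read-out.

Compound 1 `O=c1cc(OCC(O)CNC2CCCCC2)c2ccccc2o1` carries a cyclohexyl on the amine nitrogen. In an ADME assay on Vero cells (Chlorocebus sabaeus) for cytotoxicity, read by fluorescence and resazurin assay, with a stated time of 72 h (on this read-out higher numbers stand for lower toxicity in this test and lower numbers for higher toxicity in this test), compound 1 gives > 100000 nM, which is a limit of the assay and not a number. Compound 2 `O=c1cc(OCC(O)CNC2CC2)c2ccccc2o1` differs by a cyclopropyl in place of cyclohexyl on the amine nitrogen. In this assay compound 2 gives > 100000 nM, again a limit. The step that the two limits leave unreadable from compound 1 to compound 2 therefore cannot be sized. Compound 3 `CCCCCCCCCCCCNCC(O)COc1cc(=O)oc2ccccc12` carries a dodecyl chain on the amine nitrogen. In this assay compound 3 gives > 100000 nM, which is a limit as well. Among the compounds with values here, compound 3 thus stands at the same limit as the other two; the only pattern to state is the limit of > 100000 nM in this assay, at which 3 of the 3 values shown sit, and no measured step is readable.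

The next compound, compound 4 `CCCCNCC(O)COc1cc(=O)oc2ccccc12`, is made from compound 3 by the change (hydrogen in place of octyl on a saturated chain carbon, four bonds along the chain from an amine nitrogen). Within the data shown here, no measured step bears on this change, since the step from compound 1 to compound 2 is unreadable and concerns ring groups on the nitrogen rather than chain length. On the evidence of the limit of > 100000 nM in this assay, at which 3 of the 3 values shown sit, for compound 4 the step that the limit leaves unreadable from compound 3 to compound 4 is expected to be nothing readable beyond the scatter. Compound 4 is therefore estimated at 150000 nM in this assay, with a range from 60000 nM to 400000 nM, and most likely reported only as a limit.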

Compound 4, half-maximal cytotoxic concentration: > 100000 nM
Compound 4 gave a limit, no number; the forecaster's own chance of this, stated with the estimate: 85%; the middle value does not contradict the limit.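

Compound 4 stands at a limit, as do compound 1, compound 2 and compound 3, so the steps from each of these three to compound 4 cannot be read: the limit of > 100000 nM in this assay, at which 4 of the 4 values shown sit. In this assay the compounds shown leave open at what concentration, if any, toxicity would appear with any of these groups on the amine nitrogen.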